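Compound 3 to Compound 4: Replacing the Methacrylamide

A few compounds are considered here, and "the series" means these few. Any claim that something is new, unique, unknown or untested is made for them only; others in the source may bear on it.

Going by the values given here, compound 1 `O=C(Nc1ccc(Cl)cc1)c1cc([N+](=O)[O-])ccc1Cl` is one of three compounds measured in an ADME assay on HEK293 cells (Homo sapiens) for inhibition, with a stated time of 72 h; a lower number here means that less compound is needed, a higher number that more compound is needed for the effect. In this assay compound 1 gives > 25000 nM, which is a limit of the assay and not a number. Compound 2 `C=CC(=O)Nc1cccc(-c2nc3ccccc3s2)c1` carries an acrylamide on the shared core. In this assay compound 2 gives > 25000 nM, again a limit rather than a number. Compound 3 `C=C(C)C(=O)Nc1cccc(-c2nc3ccccc3s2)c1` differs from compound 2 by a step that the two limits leave unreadable from compound 2 to compound 3. In this assay compound 3 gives > 25000 nM, also a limit. Among the compounds with values here, compound 3 therefore stands where every measured compound stands, namely at the limit of > 25000 nM in this assay, at which 3 of the 3 values shown sit, so no step among them can be read.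

Compound 4 `CN(C)CCC(=O)Nc1cccc(-c2nc3ccccc3s2)c1` has not yet been measured. Its change from compound 3 is 2-(dimethylamino)ethyl in place of 1-methylethenyl on a carbonyl carbon. Within the data shown here, no measured step bears on this change, since the only measured step, a step that the two limits leave unreadable from compound 2 to compound 3, sits between two limits and gives no size. The step that the limit leaves unreadable from compound 3 to compound 4 that the estimate means is therefore expected to be small, with its direction unknown. Compound 4 is expected to give 40000 nM in this assay, within a range from 10000 nM to 150000 nM, with a high chance that only a limit is reported again.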

Compound 4, half-maximal effective concentration: > 25000 nM
Compound 4: a limit, no number; the forecaster's own chance of this, stated with the estimate: 80%; the middle value does not contradict the limit.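

In this assay compound 4 gives > 25000 nM, which is a limit of the assay and not a number. The steps from compound 2 and from compound 3 to compound 4 therefore cannot be read: the limit of > 25000 nM in this assay, at which 4 of the 4 values shown sit. The compounds shown leave open which change, if any, would give a readable number in this assay.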